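A few compounds are considered here, and "the series" means these few. Any claim that something is new, unique, unknown or untested is made for them only; others in the source may bear on it.

Compound 1 `CCOC(=O)c1c(-c2cc(F)cc(OC)c2)[nH]c2cc(OC)ccc2c1=O`: > 21500 nM
Compound 2 `CCOC(=O)c1c(-c2cccc(Cl)c2)[nH]c2cc(OC)c(Cl)cc2c1=O`: > 21500 nM

Both compounds were tested in an ADME assay on Raji cells (Homo sapiens) for cytotoxicity, read by luminescence, with a stated time of 72 h; on this read-out higher numbers stand for an effect only at larger amounts of compound and lower numbers for an effect already at smaller amounts. Compound 2 stands at > 21500 nM, which is a limit of the assay and not a number. Compound 1 gives > 21500 nM, and this too is a limit. Neither compound therefore has an exact value, and the two share (the limit of > 21500 nM in this assay, at which 2 of the 2 values shown sit).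

The next compound to be tested is compound 3 `CCOC(=O)c1c(-c2cc(F)cc(OC)c2)[nH]c2cc(OC)c(Cl)cc2c1=O`. It keeps the rest of compound 2 but has 3-fluoro-5-methoxyphenyl in place of 3-chlorophenyl on an aromatic carbon, next to the ring nitrogen: 3-fluoro-5-methoxyphenyl in place of 3-chlorophenyl on an aromatic carbon. Among the compounds with values here, no measured pair of compounds shows what a change at this place does, so no step beyond the usual scatter is expected in this assay. This expectation rests on compound 2, whose > 21500 nM is a limit, so the assay may well report only a limit again. The expected change is a step that the limit leaves unreadable from compound 2 to compound 3. The estimate for compound 3 is 22000 nM, with an expected range from 10000 nM to 45000 nM.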

Compound 3, half-maximal effective concentration: > 21500 nM
Compound 3 was reported as a limit; the forecaster's own chance of this, stated with the estimate: 85%; the middle value is on the limit's open side.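

In this assay compound 3 gives > 21500 nM and this is a limit, not a number. Within the data shown here, as compound 1 and compound 2 also stand at limits, no step among the three compounds can be read. Still open, on these data alone, is whether 3-fluoro-5-methoxyphenyl in place of 3-chlorophenyl, or chloro in place of hydrogen, changes cytotoxicity at all.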